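From Compound 2 to Compound 3: One Substitution

The source may hold more compounds than are shown below. What is called first, only, known or untested is meant among the compounds shown, and "the series" means these compounds.

Measured in a functional assay on HepG2 cells (Homo sapiens) for cytotoxicity, read by MTT assay, with a stated time of 72 h; a lower number here means a stronger inhibitor, a higher number a weaker inhibitor:
Compound 1 `CNC(=O)c1cc(Oc2ccc(C3=NNC(c4ccc(Cl)cc4Cl)C3)cc2)ccn1`: "not determined" (no result reported)
Compound 2 `CNC(=O)c1cc(Oc2ccc(C3=NNC(c4ccc(C#N)cc4)C3)cc2)ccn1`: 15000 nM

Within the data shown here, compound 2, at 15000 nM, holds the only number in this assay, while compound 1 has "not determined" (no result reported), so no ranking can be drawn. Compound 3 `CNC(=O)c1cc(Oc2ccc(C3=NN(C(N)=S)C(c4ccc(C#N)cc4)C3)cc2)ccn1` differs from compound 2 by one substitution: a group of 3 heavy atoms (1 carbon, 1 nitrogen, 1 sulfur; no ring) in place of a hydrogen atom, on an amine nitrogen in a ring. The new group stands on an amine nitrogen in a ring. Among the measured compounds shown here, no measured pair shows what such a change does, so the expectation is loose. A moderate move toward stronger inhibition is expected, estimated as a 2.1-fold lower number from compound 2 to compound 3 (0.33 log units; beyond the scatter). For compound 3 the estimated value is 7000 nM, with an expected range from 1800 nM to 30000 nM.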

Compound 3, half-maximal inhibitory concentration: > 50000 nM
Compound 3 ended at the assay's limit (the forecaster's own chance of this, stated with the estimate: 15%); middle value at least 7.1-fold (0.85 log units) from the limit.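

In this assay, among these compounds, the first readable change at this position, on the amine nitrogen in the ring, points toward weaker inhibition: the new group gives an at least 3.3-fold higher number from compound 2 to compound 3 (0.52 log units; beyond the scatter). Compound 3 gives > 50000 nM, which is a limit of the assay and not a number, so the step fixes a direction and a minimum size only. The reading stops at this point: the limit of > 50000 nM in this assay, at which 1 of the 3 values shown sits.

Going by these compounds, whether an acetyl or a methyl group on the same nitrogen would give a similar step stays open, as does the part played by the sulfur atom.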